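The source may report more compounds than this note shows. Statements on the series, on what has been measured and on what is new or still open speak of the compounds shown alone.

Within the data shown here, compound 3, with structure `CCCC[C@H](NC(=O)[C@H](CCCCN)NC(=O)[C@H](CCCNC(=N)N)NC(=O)c1ccc(/C=C2\SC(=S)N(CCCC)C2=O)cc1)C(N)=O`, is the only member of this small set with a number attached. In an ADME assay for permeability, using PAMPA (on this read-out higher numbers stand for higher permeability and lower numbers for lower permeability), compound 3 gives 1.61 10^-6 cm/s. The two companions share its peptide-like core but carry different groups on the aromatic ring. Compound 1, with structure `CCCC[C@H](NC(=O)[C@H](CCCCN)NC(=O)[C@H](CCCNC(=N)N)NC(=O)c1ccc(/C=C/C(N)=O)cc1)C(N)=O`, is described in this assay as "impermeable" (no number reported). Compound 2, with structure `CCCC[C@H](NC(=O)[C@H](CCCCN)NC(=O)[C@H](CCCNC(=N)N)NC(=O)c1ccccc1)C(N)=O`, is likewise described in this assay as "impermeable" (no number reported). Among the measured compounds shown here, since neither of those two entries comes with a number, no measured step to compound 3 can be drawn, and compound 3 simply stands alone as the one figure reported.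

The next compound, compound 4 with structure `CCCC[C@H](NC(=O)[C@H](CCCCN)NC(=O)[C@H](CCCNC(=N)N)NC(=O)c1ccc(/C=C2\SC(=S)N(c3ccc(OC)cc3)C2=O)cc1)C(N)=O`, differs from compound 3 in a single place: 4-methoxyphenyl in place of butyl on an amide-type nitrogen in a ring. For the measured compounds named here, no measured pair in this set covers a change of this kind, so the direction of the step cannot be read off from earlier results. The expectation is therefore a cautious one: the step from compound 3 to compound 4 in this assay is estimated to stay within the usual scatter, at a 1.2-fold lower number from compound 3 to compound 4 (0.09 log units; within the scatter). On that basis compound 4 is expected to give about 1.3 10^-6 cm/s in this assay, with a plausible span from 0.5 10^-6 cm/s to 3.5 10^-6 cm/s.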

Compound 4, apparent permeability: 0.59 10^-6 cm/s
Compound 4: the middle estimate sits 2.2-fold (0.34 log units) above what was measured; low and high end bracket the measured number.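

Changing the group on the ring nitrogen does register in this assay: putting 4-methoxyphenyl in place of butyl gives a 2.7-fold lower number from compound 3 to compound 4 (0.44 log units; beyond the scatter). Among these compounds, this is the first measured step in the set, and it shows that this position of the five-membered ring can shift the read-out, if only modestly. The swap changes several things at once, since the entering group has 8 heavy atoms in place of 4, one six-membered aromatic ring and a hydrogen-bond acceptor, and nothing shown here establishes which of these features lies behind the lower number.

A plain phenyl on the same nitrogen would help separate the contribution of the aromatic ring from that of its methoxy group, while a longer chain in place of butyl would test whether the read-out follows chain length at all. As far as these compounds go, a chain ending in an amine or a carboxylic acid at this position also remains open, so a single step cannot yet define a trend for this nitrogen.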